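Anilinoquinazoline thioacetamides: halogen shift on the anilino ring

The source may hold more compounds than are shown below. What is called first, only, known or untested is meant among the compounds shown, and "the series" means these compounds.

Compound 1 `O=C(CSc1nc(Nc2ccccc2)c2ccccc2n1)Nc1ccccc1Br` and compound 2 `C=CC(=O)Nc1cccc(NC(=O)CSc2nc(Nc3ccccc3F)c3ccccc3n2)c1` share the same core and differ in the arylamine and in the amide-side aryl group. In a functional assay on MDA-MB-231 cells (Homo sapiens) for inhibition, read by MTT assay, with a stated time of 72 h (a higher number here means a weaker inhibitor, a lower number a stronger inhibitor), compound 1 gives 14100 nM, and compound 2 gives 18700 nM. Compound 2 carries the higher of the two numbers, but the gap to compound 1 lies within the scatter, so no order between them is claimed.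

Compound 3 `C=CC(=O)Nc1cccc(NC(=O)CSc2nc(Nc3cccc(Cl)c3)c3ccccc3n2)c1` keeps the acrylamide-bearing side of compound 2 and changes the arylamine: 3-chlorophenyl in place of 2-fluorophenyl on a nitrogen on an aromatic ring. Going by the values given here, no step between measured compounds covers a change of this kind, so no direction is supported by the data. The expectation is therefore a step from compound 2 to compound 3 of a 1.2-fold lower number from compound 2 to compound 3 (0.10 log units; within the scatter), that is, none beyond the scatter. Compound 3 is accordingly estimated at 15000 nM, with a range from 6000 nM to 40000 nM.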

Compound 3, half-maximal inhibitory concentration: 16300 nM
Compound 3: middle estimate off by 1.1-fold (0.04 log units), on the low side, within the range that was stated.
By their numbers in this assay, from the lowest: compounds 1, 3 and 2 (each within the scatter of the next).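

Going by these compounds alone, replacing 2-fluorophenyl with 3-chlorophenyl on a nitrogen on an aromatic ring gives a 1.1-fold lower number from compound 2 to compound 3 (0.06 log units; within the scatter) in this assay, the first step that can be read at a single place. With the acrylamide-bearing side held constant, this read-out does not separate the two halogenated phenyl groups, although the halogen and its ring position change together and neither can be read alone. No evidence bearing on this result is available.

From the compounds shown here alone, whether a 2-chlorophenyl or 3-fluorophenyl group would separate the effects of halogen and ring position remains open, as does whether an amine or a carboxylic acid on this ring would give a step beyond the scatter. The contribution of the acrylamide also remains unresolved, since compound 1 and compound 2 differ in two places.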